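Cyclopropyl series: inverting both stereocentres

This account rests on a few compounds, and the source may have more. Where it says the series, first, only, none or still open, it means among the compounds named here.

Among the measured compounds shown here, compound 2 `c1ccc([C@@H]2C[C@H]2C2=NCCN2)cc1` shows the higher of the two numbers so far: in an assay (Oryctolagus cuniculus) for displacement of a labelled ligand from Monoamine oxidase (Homo sapiens) (a higher number here means a weaker inhibitor, a lower number a stronger inhibitor), compound 2 gives 6.03 nM, while compound 1 `C(=C/c1ccccc1)\C1=NCCN1` gives 1.91 nM, a lower number that lies beyond the usual scatter. Compound 3 `c1ccc([C@H]2C[C@@H]2C2=NCCN2)cc1` is the mirror image of compound 2: the two compounds have the same atoms and bonds and differ only in configuration as drawn: 2 of 2 stereo elements differ (all stereocentres are inverted: mirror images); a stereocentre at a saturated ring carbon is drawn R in compound 2 and S in compound 3; a stereocentre at a saturated ring carbon is drawn R in compound 2 and S in compound 3. For the measured compounds named here, no pair of measured mirror images exists, so the direction of the change from compound 2 to compound 3 cannot be read from what is known; a moderate step either way is as plausible as none beyond the scatter. Compound 3 is expected to give about 8 nM in this assay, within 1.5 nM to 40 nM, an estimated step of a 1.3-fold higher number from compound 2 to compound 3 (0.12 log units; within the scatter).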

Compound 3, inhibition constant: 123 nM
Estimate against measurement, compound 3: 15-fold (1.19 log units) below; measured number outside the range, above it.
By their numbers in this assay, from the lowest: compound 1; then compound 2; then compound 3.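

Inverting both stereocentres produces a 20-fold higher number from compound 2 to compound 3 (1.31 log units; beyond the scatter) in this assay. Among the compounds shown here, this is the first measured pair of mirror images, and it shows that the configuration at the two saturated ring carbons matters here, with the arrangement drawn in compound 2 giving the lower number. The step is attributable to configuration alone, because nothing else changes: the fact that compounds 2 and 3 differ only in the configuration as drawn

Still open, from the compounds shown here alone, is how a form with only one of the two stereocentres inverted would compare. Going by these compounds, it is also open whether the same preference would hold if the core of compound 2 carried a methoxy group or a longer chain.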